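Swapping Isopropyl for Cyclopropyl on a Weak Agonist

The compounds below may be only part of what the source reports. "The series", "measured", "known", "first", "only" and "open" are said of these compounds alone.

Of the compounds shown here, three have been tested in a functional assay on CHO-K1 cells for agonist activity at G-protein coupled receptor 6 (Homo sapiens), read by TR-FRET and cAMP accumulation, with a stated time of 20 h; a higher number here means that more compound is needed for the effect, a lower number that less compound is needed. Compound 1 `Cc1cc2nc(NC3CC3)c(N3CCC(Oc4ccc(F)cc4F)CC3)nc2cn1` gives 29000 nM, and compound 2 `CC(C)Nc1nc2c(nc1N1CCN(Cc3ccc(F)cc3F)CC1)C=CN(S(C)(=O)=O)C2` gives 27000 nM. Compound 3 `CC(=O)N1C=Cc2nc(NC(C)C)c(N3CCC(Oc4ccc(F)cc4F)CC3)nc2C1` gives 96000 nM, the highest of the three numbers, standing beyond the scatter above both of the others. Compound 4 `CC(=O)N1C=Cc2nc(NC3CC3)c(N3CCC(Oc4ccc(F)cc4F)CC3)nc2C1` is compound 3 with a single change: cyclopropyl in place of isopropyl on a nitrogen on an aromatic ring. Among the compounds with values here, no measured pair shows this change on its own; compound 1 carries the cyclopropyl group but also a different core, so the 29000 nM of compound 1 cannot be credited to that group alone. The step of a 1.6-fold lower number from compound 3 to compound 4 (0.20 log units; within the scatter) is expected to be small, within the scatter. Compound 4 is estimated at 60000 nM, with a plausible range from 20000 nM to 180000 nM.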

Compound 4, half-maximal effective concentration: 34000 nM
The estimate for compound 4 lay 1.8-fold (0.25 log units) above the measured number, and the stated range covers the measured number.
By their numbers in this assay, from the lowest: compounds 2, 1 and 4 (each within the scatter of the next); then compound 3.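

Within the data shown here, this is the first pair of compounds that differ only at this position, and it isolates the change. In this assay, cyclopropyl in place of isopropyl on a nitrogen on an aromatic ring gives a 2.8-fold lower number from compound 3 to compound 4 (0.45 log units; beyond the scatter) as a modest step, even though the count of heavy atoms stays the same. Nothing available explains the size of this step. As far as these compounds go, whether a cyclobutyl group or a longer chain such as n-butyl on this nitrogen would lower the number further remains open, as does whether the same swap gives a similar step on the core of compound 1.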